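A few compounds are considered here, and "the series" means these few. Any claim that something is new, unique, unknown or untested is made for them only; others in the source may bear on it.

Measured in a functional assay on PC-3 cells (Homo sapiens) for antiproliferative activity, read by MTT assay, with a stated time of 24 h; a lower number here means a stronger inhibitor, a higher number a weaker inhibitor:
- compound 1 `CCn1c(C(=O)NC(C)(C)CO)ccc1C(CC)(CC)c1ccc(OCS(=O)(=O)c2ccccc2)c(C)c1` gives 9850 nM
- compound 2 `CCN(CC)CCNC(=O)c1cc(C(CC)(CC)c2ccc(OCSC)c(C)c2)cn1CC` gives 9540 nM

These two numbers lie within the usual scatter of each other, so compound 2 shares its standing with compound 1 and neither can be ranked above the other. The next compound to be tested is compound 3 `CCN(CC)CCNC(=O)c1cc(C(CC)(CC)c2ccc(OCS(C)(=O)=O)c(C)c2)cn1CC`, which has methylsulfonyl in place of methylsulfanyl on a saturated chain carbon bound to an oxygen on an aromatic ring, and the change is methylsulfonyl in place of methylsulfanyl on a saturated chain carbon bound to an oxygen on an aromatic ring. Among the measured compounds shown here, no measured pair isolates this change, since compound 1 and compound 2 differ in more than one place. With so little to go on, no step beyond the scatter is expected in this assay, and no direction is favoured. The estimate is a 1.1-fold lower number from compound 2 to compound 3 (0.03 log units; within the scatter), which would stay within the scatter. Compound 3 is expected at 9000 nM, within an estimated range of 4000 nM to 20000 nM.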

Compound 3, half-maximal inhibitory concentration: 36600 nM
Compound 3: the middle estimate sits 4.1-fold (0.61 log units) below what was measured; measured number outside the range, above it.
By their numbers in this assay, from the lowest: compounds 2 and 1 (each within the scatter of the next); then compound 3.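

In this assay, among the compounds shown here, the first comparison of compounds that differ in only one place shows that this position is sensitive to change. Methylsulfonyl in place of methylsulfanyl, on a saturated chain carbon bound to an oxygen on an aromatic ring, gives a 3.8-fold higher number from compound 2 to compound 3 (0.58 log units; beyond the scatter), so the added oxygen atoms on the sulfur go with weaker inhibition on this core. No measurement available here bears on the reason for this loss.

From the compounds shown here alone, this is a single pair, so it remains open whether the same change would weaken inhibition on a different core. Going by these compounds, it also remains open how methylsulfinyl, which has one oxygen on the sulfur, or a longer chain on the sulfur, such as ethylsulfanyl, would compare in this place.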